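The source may hold more compounds than are shown below. What is called first, only, known or untested is meant among the compounds shown, and "the series" means these compounds.

Working notes on the series. In an assay on cells for inhibition of Voltage-dependent T-type calcium channel subunit alpha-1G (Homo sapiens), read by patch clamp, tested at 10 uM (a lower number here means less inhibition, a higher number more inhibition at the concentration tested (going by the name of the read-out)), compound 1 `CN(C)CCCCCSC1=Nc2ccccc2C(CC(=O)NCc2ccccc2)N1c1ccc(-c2ccc(F)cc2)cc1` gives 97.6%, compound 2 `CN(C)CCCCCSC1=Nc2ccccc2C(CC(=O)NCc2ccccc2)N1c1ccc(-c2ccccc2)cc1` gives 76.2%, and compound 3 `CN(C)CCCCCSC1=Nc2ccccc2C(CC(=O)NCc2ccc(F)cc2)N1c1ccc(-c2ccccc2)cc1` gives 31%. Compound 2 thus stands second highest of the three measured numbers, with a number 21.4 percentage points lower from compound 1 to compound 2 (beyond the scatter) on one side and a number 45.2 percentage points lower from compound 2 to compound 3 (beyond the scatter) on the other. Compound 4 `O=C(CC1c2ccccc2N=C(SCCCCCN2CCCC2)N1c1ccc(-c2ccccc2)cc1)NCc1ccccc1` differs from compound 2 by pyrrolidin-1-yl in place of dimethylamino on a saturated chain carbon, five bonds along the chain from a sulfur. For the measured compounds named here, neither measured step bears on this change: both concern a fluoro on an aromatic carbon, not the dimethylamino on the saturated chain carbon, so the series holds no step informing it. No step beyond the scatter is therefore expected; the estimate corresponds to a number 2.2 percentage points lower from compound 2 to compound 4 (within the scatter). For compound 4 the expected value is 74%, with a range from 50% to 92%.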

Compound 4, a percentage reported as inhibition, at one concentration (the size of the read-out at that concentration, not a potency): 93.9%
For compound 4 the middle estimate is 19.9 percentage points below the measured one; measured number above the stated range.
By their numbers in this assay, from the lowest: compound 3; then compound 2; then compounds 4 and 1 (each within the scatter of the next).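

In this assay, the position on a saturated chain carbon, five bonds along the chain from a sulfur, proves responsive to the amine group it carries: pyrrolidin-1-yl in place of dimethylamino gives a number 17.7 percentage points higher from compound 2 to compound 4 (beyond the scatter). The series' read-out therefore changes with a change at this chain position, not only with fluoro changes on aromatic carbons. No measurement at hand explains this step.

From the compounds shown here alone, whether the ring itself or the added carbons matter remains open, since dimethylamino and pyrrolidin-1-yl alone cannot separate them. Piperidin-1-yl, morpholin-4-yl, diethylamino and a shorter chain at this place also remain open.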